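This account rests on a few compounds, and the source may have more. Where it says the series, first, only, none or still open, it means among the compounds named here.

Measured so far:
compound 1 `COc1nn(Cc2ccccc2)c(=O)o1` — "not active" (no number reported)
compound 2 `COc1nn(Cc2cccc([N+](=O)[O-])c2)c(=O)o1` — 7%
compound 3 `COc1nn(Cc2cccc(NC(C)=O)c2)c(=O)o1` — "not active" (no number reported)

All three compounds share one core and differ only in a group on the benzyl ring. In an assay on COS-7 cells for inhibition of Fatty-acid amide hydrolase 1 (Homo sapiens), read by scintillation counting, with a stated time of 10 min, tested at 10 uM (a higher number here means more inhibition at the concentration tested (going by the name of the read-out), a lower number less inhibition), compound 1 gives "not active" (no number reported). In this assay compound 2 gives 7%, a small read-out at the single concentration tested. In this assay compound 3 gives "not active" (no number reported), so no number stands for it; it is one of two entries in this assay without a single number, and the only numbered result, that of compound 2, is itself small.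

The next compound, compound 4 `COc1nn(Cc2cccc(C#N)c2)c(=O)o1`, changes compound 3 in one place: cyano in place of acetamido on an aromatic carbon. Nothing in the measured set shows a benzyl group that lifts inhibition clearly above the scatter, so no sizable step in either direction is expected in this assay; the read-out for compound 4 should stay in the same low region as that of compound 2 and the two unnumbered entries.

Compound 4 is therefore estimated to give about 5% in this assay, with a likely range from 0% to 15%, and a real chance that only "not active" is reported.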

Compound 4, a percentage reported as inhibition, at one concentration (the size of the read-out at that concentration, not a potency): "not active" (no number reported)
Compound 4: no number reported; there is nothing to compare the estimate with.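

In this assay compound 3 gives "not active" (no number reported) and compound 4 gives "not active" (no number reported), so no step can be read between these two compounds. No measured evidence bears on this result. The compounds shown leave open whether cyano in place of acetamido changes inhibition at all, and whether any benzyl group can raise it clearly.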